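The source may report more compounds than this note shows. Statements on the series, on what has been measured and on what is new or still open speak of the compounds shown alone.

Compound 1 `CC(C)NC1=NS(=O)(=O)c2cc(Cl)ccc2N1`: 36.3 uM
Compound 2 `CNC1=NS(=O)(=O)c2cc(F)ccc2N1`: > 300 uM

In a functional assay (aorta) with Rattus norvegicus as the target (on this read-out higher numbers stand for an effect only at larger amounts of compound and lower numbers for an effect already at smaller amounts), compound 2 gives no exact number. Its > 300 uM is a limit of the assay, so compound 2 has no exact position on the scale.

Compound 3 `CCNC1=NS(=O)(=O)c2cc(F)ccc2N1` differs from compound 2 in one place, where methylamino becomes ethylamino: methyl in place of hydrogen on a saturated chain carbon bound to an amine nitrogen. This is methyl in place of hydrogen on a saturated chain carbon bound to an amine nitrogen. Among the measured compounds shown here, no measured pair shows this change alone, so any expectation is loose. Still, compound 1 at 36.3 uM shows that a related structure gives a measurable effect. A modest shift towards effect at smaller amounts is expected, and the estimated step is an at least 2.0-fold lower number from compound 2 to compound 3 (0.30 log units; that floor lies within the scatter). For compound 3, the expected value is 150 uM, within an estimated range of 50 uM to 400 uM.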

Compound 3, concentration for half-maximal effect: > 300 uM
Compound 3: no number, only a limit (the forecaster's own chance of this, stated with the estimate: 45%); middle value at least 2.0-fold (0.30 log units) away from the limit.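

Compound 3 gives > 300 uM, which is a limit of the assay and not a number. No step from compound 2 to compound 3 can be read, because both compounds sit at the same limit: the limit of > 300 uM in this assay, at which 2 of the 3 values shown sit.

The compounds shown leave open what changing methylamino to ethylamino does to the effect.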